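A few compounds are considered here, and "the series" means these few. Any claim that something is new, unique, unknown or untested is made for them only; others in the source may bear on it.

Measured so far:

Compound 1, `Nc1ncc(-c2ccncc2-c2ccccc2)c(C2CC2)n1`, in a functional assay on CUTLL1 cells (Homo sapiens) for inhibition, read by resazurin assay, with a stated time of 48 h, in the absence of a further agent (a higher number here means that more compound is needed for the effect, a lower number that less compound is needed), gives > 100000 nM; this is a limit of the assay, not a number.
Compound 2, `Nc1ncc(-c2ccncc2-c2ccoc2)c(C2CC2)n1`, in this assay gives 28000 nM.
Compound 3, `Nc1ncc(-c2ccncc2)c(-c2ccccc2)n1`, in this assay gives > 100000 nM; this too is a limit of the assay.

Compound 1 and compound 2 share a core and differ in one place: furan-3-yl in place of phenyl on an aromatic carbon. This change gave an at least 3.5-fold lower number from compound 1 to compound 2 (0.55 log units; beyond the scatter). Compound 3 carries a different core; how the two cores differ is not broken down here.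

Compound 4, `Nc1ncc(-c2ccncc2)c(-c2ccoc2)n1`, has not yet been measured. It stands to compound 3 as compound 2 stands to compound 1: furan-3-yl in place of phenyl on an aromatic carbon. The surroundings of the place are not the same, though. In compound 1 the change sits on an aromatic carbon of a six-membered aromatic ring with 1 nitrogen, ortho to a large group, two atoms from the ring nitrogen; in compound 3 it sits on a six-membered aromatic ring with 2 nitrogen, next to the ring nitrogen, ortho to a pyridin-4-yl group, meta to an amino group, opposite the ring nitrogen. So this is the same kind of change, not the same change.

Because of the limit of > 100000 nM in this assay, at which 2 of the 3 values shown sit, the starting point of compound 3 is only known as a limit, and the size of the earlier step is itself only known as a floor. Resting on an at least 3.5-fold lower number from compound 1 to compound 2 (0.55 log units; beyond the scatter), the step from compound 3 to compound 4 is expected to be an at least 2.2-fold lower number from compound 3 to compound 4 (0.34 log units; beyond the scatter). Compound 4 is therefore estimated at 45000 nM in this assay, somewhere between 15000 nM and 150000 nM, with a real chance that only a limit is reported again.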

Compound 4, half-maximal effective concentration: > 100000 nM
Compound 4 gave a limit, no number; the forecaster's own chance of this, stated with the estimate: 45%; at least 2.2-fold (0.34 log units) between middle value and limit.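

Among these compounds, no step from compound 3 to compound 4 can be read, because both compounds give only a limit and no number: the limit of > 100000 nM in this assay, at which 3 of the 4 values shown sit.

The compounds shown leave open whether furan-3-yl in place of phenyl changes the number in this assay at all on the core of compound 3, and whether the lower number seen on going from compound 1 to compound 2 carries over to that core.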